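A few compounds are considered here, and "the series" means these few. Any claim that something is new, unique, unknown or untested is made for them only; others in the source may bear on it.

Measured so far:
- compound 1, `O=C(Nc1cccc(-n2cc(-c3ccncc3)c(-c3cc(O)cc(Cl)c3)n2)c1)Nc1ccc(Cl)c(C(F)(F)F)c1`: -3%
- compound 2, `COc1cc(Cl)cc(-c2nn(-c3cccc(NC(=O)Nc4ccc(Cl)c(C(F)(F)F)c4)c3)cc2-c2ccncc2)c1`: -29%
- compound 3, `COc1cc(Cl)cc(-c2nn(-c3cccc(NC(=O)Nc4cc(C(F)(F)F)cc(C(F)(F)F)c4)c3)cc2-c2ccncc2)c1`: -29%

In a functional assay on CCRF-CEM cells (Homo sapiens) for inhibition, read by sulforhodamine B assay, with a stated time of 48 h, tested at 100 uM (a higher number here means a weaker effect of the compound at the concentration tested, a lower number a stronger effect), compound 2 gives -29%, level at the digits printed with compound 3, which gives -29%; together these are the lowest of the three numbers, and compound 1 sits higher, giving -3%. Within the data shown here, the only step recorded, a number 26 percentage points lower from compound 1 to compound 2 (beyond the scatter), concerns a change on an oxygen and does not touch the ring altered here.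

Compound 4, `COc1cc(Cl)cc(-c2nn(-c3cccc(NC(=O)Nc4ccc(Cl)c(Cl)c4)c3)cc2-c2ccncc2)c1`, differs from compound 2 by chloro in place of trifluoromethyl on an aromatic carbon. Among the measured compounds shown here, no measured step bears on this ring directly; compounds 2 and 3 carry different substituents on the same ring and show the same value, so the one comparison available on this part of the structure shows no difference. On that basis no step beyond the scatter is expected in this assay, and the estimated step is no change at the digits printed from compound 2 to compound 4 (within the scatter). Compound 4 is therefore expected to give -29%, within a range from -45% to -10%.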

Compound 4, a percentage reported as activity, at one concentration (the size of the read-out at that concentration, not a potency): -27%
The estimate for compound 4 lay 2 percentage points below the measured number; measured number inside the range.
By their numbers in this assay, from the lowest: compounds 2, 3 and 4 (each within the scatter of the next); then compound 1.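

In this assay, the series now has its first change in one place on the urea's outer aryl ring, 4-chloro-3-(trifluoromethyl)phenyl to 3,4-dichlorophenyl, and it reads as a number 2 percentage points higher from compound 2 to compound 4 (within the scatter). At this position, ortho to a chloro group, one chlorine atom therefore stands in for the four heavy atoms of trifluoromethyl without a step beyond the scatter at the single concentration tested. No measurement available here accounts for this outcome.

Still open, as far as these compounds go, is whether this position accepts groups of another kind, such as a primary amine, a carboxylic acid or a longer alkyl chain, in place of chloro or trifluoromethyl. Also open, from the compounds shown here alone, is whether the same exchange reads alike on the hydroxy-bearing scaffold of compound 1.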